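Ethoxy for phenoxy on the aryl ether of compound 3

The source may hold more compounds than are shown below. What is called first, only, known or untested is meant among the compounds shown, and "the series" means these compounds.

Three compounds of this series have numbers in a functional assay on A549 cells (Homo sapiens) for inhibition, read by sulforhodamine B assay, with a stated time of 48 h, tested at 50 uM; on this read-out higher numbers stand for more inhibition of growth at the one concentration tested and lower numbers for less inhibition of growth. Compound 1 `COc1cc2c(cc1CC=C(C)C)/C(=N/NC(N)=O)C[C@@H](c1ccc(O)cc1)O2` gives 77%, compound 2 `COc1ccc([C@@H]2C/C(=N/OCc3cn(-c4ccc(Cl)cc4C)nn3)c3cc(CC=C(C)C)c(OC)cc3O2)cc1` gives 35%, and compound 3 `COc1cc2c(cc1CC=C(C)C)C(=O)C[C@@H](c1ccc(Oc3ccccc3)cc1)O2` gives 46%. Compound 3 stands second of the three: its number lies above that of compound 2 and well below that of compound 1, both gaps beyond the scatter. Compound 4 `CCOc1ccc([C@@H]2CC(=O)c3cc(CC=C(C)C)c(OC)cc3O2)cc1` differs from compound 3 in one place: ethyl in place of phenyl on an oxygen on an aromatic ring. For the measured compounds named here, no step between two measured compounds isolates this change, so nothing shows its direction. The step from compound 3 to compound 4 is therefore expected to be small, not beyond the scatter, as no change at the digits printed from compound 3 to compound 4 (within the scatter). Compound 4 is expected at 46%, within 30% to 62%.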

Compound 4, percent growth inhibition at one concentration: 37%
Estimate against measurement, compound 4: 9 percentage points above; the range from low to high includes it.
By their numbers in this assay, from the lowest: compounds 2, 4 and 3 (each within the scatter of the next, the first and the last beyond it); then compound 1.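

In this assay, for the compounds shown here, the phenoxy to ethoxy change gives a number 9 percentage points lower from compound 3 to compound 4 (within the scatter) and is the first step that isolates this position. On this read-out, at the one concentration tested, the phenyl on this oxygen can give way to ethyl with no difference beyond the scatter, so the aromatic ring there is not required to keep this level of growth inhibition. No measurement at hand bears on the reason for this.

Open, from the compounds shown here alone, is how a longer chain, an amine or a carboxylic acid on this oxygen would read. Also open, going by these compounds, is whether the same step holds on the oxime and semicarbazone forms of compounds 1 and 2.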